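A few compounds are considered here, and "the series" means these few. Any claim that something is new, unique, unknown or untested is made for them only; others in the source may bear on it.

Measured so far in a functional assay on U-87MG ATCC cells (Homo sapiens) for antiproliferative activity; a lower number here means a stronger inhibitor, a higher number a weaker inhibitor:
compound 1 `Cc1c2c(n3c1CCCNC[C@H](C)Nc1cc-3ccc1C(N)=O)CC(C)(C)CC2=O` gives 366 nM
compound 2 `Cc1c2c(n3c1CCN(C)C[C@@H](C)[C@H](C)Nc1cc-3ccc1C(N)=O)CC(C)(C)CC2=O` gives 49 nM
compound 3 `Cc1c2c(n3c1CCCN(C(=O)CN)[C@@H](C)[C@H](C)Nc1cc-3ccc1C(N)=O)CC(C)(C)CC2=O` gives 481 nM

Compound 2 has the lowest number of the three, and its gaps to compound 1 and compound 3 both lie beyond the scatter. Compound 4 `Cc1c2c(n3c1CCN(C(=O)C1(N)CCCC1)C[C@@H](C)[C@H](C)Nc1cc-3ccc1C(N)=O)CC(C)(C)CC2=O` differs from compound 2 at one place: a group of 8 heavy atoms (6 carbon, 1 nitrogen, 1 oxygen; one five-membered non-aromatic ring of carbon only) in place of one carbon atom, on an amine nitrogen in a ring on an amine nitrogen in a ring. Going by the values given here, no single-place step between measured compounds is available, so the evidence is thin. Compound 3, which also bears a carbonyl group on a ring nitrogen but differs elsewhere too, gives 481 nM in this series. A weakening beyond the scatter is expected in this assay, estimated as a 5.1-fold higher number from compound 2 to compound 4 (0.71 log units; beyond the scatter) in size. The estimate for compound 4 is 250 nM with an expected range from 70 nM to 900 nM as its span.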

Compound 4, half-maximal inhibitory concentration: 44 nM
For compound 4 the middle estimate is 5.7-fold (0.75 log units) above the measured one; the measured number lies below the stated range.
By their numbers in this assay, from the lowest: compounds 4 and 2 (each within the scatter of the next); then compounds 1 and 3 (each within the scatter of the next).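

Going by these compounds alone, at the amine nitrogen in a ring, a group of 8 heavy atoms with one five-membered non-aromatic ring of carbon only can replace the methyl in this assay, with a 1.1-fold lower number from compound 2 to compound 4 (0.05 log units; within the scatter) as the first single-place step. This substitution leaves the number within the scatter, so a much larger group at this position is compatible with the activity of compound 2. No measurement bearing on the reason for this result is available. Going by these compounds, whether an acetyl group, a carboxylic acid or a longer chain on this nitrogen would give a similar number remains open.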